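This account rests on a few compounds, and the source may have more. Where it says the series, first, only, none or still open, it means among the compounds named here.

Measured so far:
compound 1, `CCN(Cc1cccn1C)C(=O)COc1ccc(C)cc1`, 21300 nM
compound 2, `Cc1ccc(OCC(=O)N(Cc2cccs2)C2CCCCC2)cc1`, 40000 nM

Of the compounds shown here, two have been measured in an assay on HEK293 cells for agonist activity at transient receptor potential cation channel subfamily M member 8 (Homo sapiens), read by fluorescence and calcium flux, with a stated time of 15 min; a lower number here means that less compound is needed, a higher number that more compound is needed for the effect. Compound 1 gives 21300 nM, and compound 2 gives 40000 nM. Compound 2 holds the higher of the two numbers, but the gap to compound 1 lies within the usual scatter of this assay, so the two cannot be told apart on these data; both need a large amount of compound to produce the effect.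

Compound 3, `Cc1ccc(OCC(=O)N(Cc2cccs2)c2c(C)n[nH]c2C)cc1`, has not yet been measured. It differs from compound 2 in a single place: 3,5-dimethyl-1H-pyrazol-4-yl in place of cyclohexyl on an amide-type nitrogen. Among the compounds with values here, no step between two measured compounds that differ in only one place is available, so there is no direct guide to how this exchange plays out in this assay. Within the data shown here, since the only two numbers known are close to each other and both high, the expectation for compound 3 is a step from compound 2 of about a 1.1-fold lower number from compound 2 to compound 3 (0.06 log units; within the scatter), that is, no clear change beyond the scatter. Compound 3 is therefore estimated at 35000 nM, with a range from 10000 nM to 120000 nM.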

Compound 3, half-maximal effective concentration: 0.3 nM
Beside the measured number, compound 3's estimate is 120000-fold (5.07 log units) above it; measured number outside the range, below it.
By their numbers in this assay, from the lowest: compound 3; then compounds 1 and 2 (each within the scatter of the next).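

The group on the amide-type nitrogen proves decisive in this assay: with everything else unchanged, 3,5-dimethyl-1H-pyrazol-4-yl in place of cyclohexyl gives a 130000-fold lower number from compound 2 to compound 3 (5.12 log units; beyond the scatter), far beyond the scatter. The earlier numbers gave no hint that one exchange at this position could matter so much, and this exchange alters several things at once, replacing a six-membered non-aromatic ring of carbon only with a five-membered aromatic ring with 2 hetero atoms, 1 hydrogen-bond donor and 1 hydrogen-bond acceptor. No measurement at hand explains why the step is so large.

As far as these compounds go, it remains open which of these differences matters, and whether the two methyl groups are needed, something that an unsubstituted pyrazol-4-yl group or a phenyl ring in the same place would help to show. From the compounds shown here alone, it is equally open whether the hydrogen on the ring nitrogen matters, which a 1,3,5-trimethylpyrazol-4-yl group on the amide-type nitrogen would test.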